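The compounds below may be only part of what the source reports. "The series", "measured", "known", "first", "only" and "open" are said of these compounds alone.

Working notes on the series. Within the data shown here, compound 1 `COc1ccc2c(=O)c(/C=C/C(=O)NCc3ccccc3)coc2c1` gives in a functional assay on HeLa cells (Homo sapiens) for inhibition, read by MTT assay, with a stated time of 48 h (on this read-out lower numbers stand for stronger inhibition and higher numbers for weaker inhibition), a value of 33400 nM and is the only compound of the three with a number rather than a limit. Compound 2 `COc1ccc2c(=O)c(/C=C/C(=O)Nc3ccccc3OC)coc2c1` gives in this assay > 100000 nM, which is a limit of the assay. The step of an at least 2.9-fold higher number from compound 1 to compound 2 (0.47 log units; beyond the scatter) is at least modest and points to weaker inhibition. Compound 3 `COc1ccc2c(=O)c(/C=C/C(=O)NCc3ccc(C)cc3)coc2c1` gives in this assay > 100000 nM, again a limit of the assay. The step of an at least 2.9-fold higher number from compound 1 to compound 3 (0.47 log units; beyond the scatter) likewise points to weaker inhibition. The step that the two limits leave unreadable from compound 2 to compound 3 cannot be read, since both ends are limits; this is the situation described by the limit of > 100000 nM in this assay, at which 2 of the 3 values shown sit. Compound 3 therefore stands only at a limit, with no number beneath it.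

Compound 4 `COc1ccc2c(=O)c(/C=C/C(=O)Nc3ccc(Cl)cc3)coc2c1` differs from compound 3 by 4-chlorophenyl in place of 4-methylbenzyl on an amide-type nitrogen. The amide nitrogen of compound 4 carries an aryl group as in compound 2, and compound 2 reached only a limit; both steps that could be read, an at least 2.9-fold higher number from compound 1 to compound 2 (0.47 log units; beyond the scatter) and an at least 2.9-fold higher number from compound 1 to compound 3 (0.47 log units; beyond the scatter), went towards weaker inhibition. Compound 4 is therefore expected to sit at or near the same limit, so the expected step of a number no higher from compound 3 to compound 4 (the limit leaves the size open) is unlikely to be readable. The estimate for compound 4 is 100000 nM, in the range 30000 nM to 300000 nM.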

Compound 4, half-maximal inhibitory concentration: > 100000 nM
Compound 4: no number, only a limit; the forecaster's own chance of this, stated with the estimate: 65%; the middle value sits exactly at the limit.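

Putting 4-chlorophenyl in place of benzyl on the amide-type nitrogen gives an at least 2.9-fold higher number from compound 1 to compound 4 (0.47 log units; beyond the scatter), so all three changes from benzyl shown in this assay now point towards weaker inhibition, and none of these compounds goes against that. Compound 4 gives > 100000 nM, which is a limit of the assay, so a chlorine-bearing aryl group joins 2-methoxyphenyl and 4-methylbenzyl without yielding a number. The steps among compound 2, compound 3 and compound 4 cannot be read, since both ends of each are limits: the limit of > 100000 nM in this assay, at which 3 of the 4 values shown sit.

Going by these compounds, the true size of each step from compound 1 stays open, as does any ranking among the three compounds at the limit. On these data alone, whether unsubstituted phenyl, a longer chain such as 2-phenylethyl, or an amine on the benzyl ring would give a number in this assay also remains open.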